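A few compounds are considered here, and "the series" means these few. Any claim that something is new, unique, unknown or untested is made for them only; others in the source may bear on it.

Measured compounds in a functional assay on MCF7 cells (Homo sapiens), read by MTT assay, with a stated time of 48 h; a higher number here means a weaker inhibitor, a lower number a stronger inhibitor:
- Compound 1 `CCOC(=O)CN(C)C(=O)c1ccc(C(CC)(CC)c2ccc(OCC(O)C(C)(C)C)c(C)c2)n1CC` gives 9200 nM.
- Compound 2 `CCn1c(C(=O)NCCN)ccc1C(CC)(CC)c1ccc(OCC(O)C(C)(C)C)c(C)c1` gives 5.9 nM.
- Compound 3 `CCn1c(C(=O)N(C)CCC#N)ccc1C(CC)(CC)c1ccc(OCC(O)C(C)(C)C)c(C)c1` gives only a limit of the assay, > 50000 nM.

Compound 1 stands as the highest of the two numbers shown, its nearest neighbour being compound 2, reached by a 1600-fold lower number from compound 1 to compound 2 (3.19 log units; beyond the scatter). Compound 3 sits at the limit of > 50000 nM in this assay, at which 1 of the 3 values shown sits, so its distance from compound 1 is known only as an at least 5.4-fold higher number from compound 1 to compound 3 (0.73 log units; beyond the scatter), and from compound 2 only as an at least 8400-fold higher number from compound 2 to compound 3 (3.92 log units; beyond the scatter).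

The step to compound 4 `CCn1c(C(=O)N(C)CC(=O)O)ccc1C(CC)(CC)c1ccc(OCC(O)C(C)(C)C)c(C)c1` is hydrogen in place of ethyl on an oxygen next to a carbonyl group. Among the measured compounds shown here, no measured step makes this same change. The two steps that start from compound 1 point in opposite directions: a 1600-fold lower number from compound 1 to compound 2 (3.19 log units; beyond the scatter), where (2-aminoethyl)amino enters, and an at least 5.4-fold higher number from compound 1 to compound 3 (0.73 log units; beyond the scatter), where cyanomethyl replaces ethoxycarbonyl on the same chain carbon. Of these, the second is the closer comparison, since it also alters the ethoxycarbonyl group while keeping the methyl on the amide nitrogen. The change to carboxymethyl is therefore expected to leave compound 4 weaker than compound 1 by a modest margin, with the step of a 2.0-fold higher number from compound 1 to compound 4 (0.29 log units; within the scatter) estimated to lie close to the edge of the scatter. Compound 4 is thus expected to give about 18000 nM in this assay, with a range from 4000 nM to 60000 nM.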

Compound 4, half-maximal inhibitory concentration: 25400 nM
Beside the measured number, compound 4's estimate is 1.4-fold (0.15 log units) below it; the range from low to high includes it.
By their numbers in this assay, from the lowest: compound 2; then compound 1; then compound 4. At a limit, above all of these: compound 3.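

In this assay, among the compounds shown here, the change from ethoxycarbonyl to carboxy is the first measured change confined to the end of the (ethoxycarbonyl)methyl chain, and it gives a 2.8-fold higher number from compound 1 to compound 4 (0.44 log units; beyond the scatter), a modest step that is small beside the large one that (2-aminoethyl)amino brings: a 1600-fold lower number from compound 1 to compound 2 (3.19 log units; beyond the scatter). The acid therefore stays on the same side of the series as the ethyl ester, as the large gap to the amine shows when read the other way: a 4300-fold higher number from compound 2 to compound 4 (3.63 log units; beyond the scatter). Compound 3 stands only at a limit of the assay: the limit of > 50000 nM in this assay, at which 1 of the 4 values shown sits. That leaves only an at least 1.9-fold lower number from compound 3 to compound 4 (0.29 log units; that floor lies within the scatter), and no order follows from it.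

What these compounds leave open is whether the large gap belongs to the terminal primary amine, to the hydrogen in place of methyl on the amide nitrogen, or to both, since compound 2 differs from compound 1, compound 3 and compound 4 in both respects at once. A (2-aminoethyl)(methyl)amino group would separate the two, while a dimethylamine at the chain end, a longer chain carrying the amine, or a primary amide in place of the carboxy group would show how narrowly this end of the molecule is defined.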